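The compounds below may be only part of what the source reports. "The series", "measured", "known", "first", "only" and "open" are said of these compounds alone.

For the measured compounds named here, compound 1 `CCCCc1ccc(CN(Cc2ccccc2)C(C)=O)c(=O)n1Cc1ccc(-c2ccccc2-c2nn[nH]n2)cc1` is the strongest of the three measured members in a functional assay (aorta) for antagonist activity, with Oryctolagus cuniculus as the target (a lower number here means a stronger inhibitor, a higher number a weaker inhibitor), where compound 1 gives 1 nM. Its nearest neighbour is compound 2 `CCCCc1ccc(C)c(=O)n1Cc1ccc(-c2ccccc2-c2nn[nH]n2)cc1`, which gives 7 nM, a 7.0-fold higher number from compound 1 to compound 2 (0.85 log units; beyond the scatter). Furthest away is compound 3 `CCCCc1ccc(CNC(=O)NC2CCCCC2)c(=O)n1Cc1ccc(-c2ccccc2-c2nn[nH]n2)cc1`, which gives 90 nM, a 90-fold higher number from compound 1 to compound 3 (1.95 log units; beyond the scatter); between the two weaker compounds the gap is a 13-fold higher number from compound 2 to compound 3 (1.11 log units; beyond the scatter).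

Compound 4 `CCCCc1ccc(CNC(=O)OC(C)(C)C)c(=O)n1Cc1ccc(-c2ccccc2-c2nn[nH]n2)cc1` differs from compound 1 in one place: (tert-butoxycarbonyl)amino in place of acetyl(benzyl)amino on a saturated chain carbon bound to an aromatic carbon. Going by the values given here, two measured steps bear on this. Removing the acetyl(benzyl)amino group altogether costs a 7.0-fold higher number from compound 1 to compound 2 (0.85 log units; beyond the scatter), and exchanging it for (cyclohexylcarbamoyl)amino costs a 90-fold higher number from compound 1 to compound 3 (1.95 log units; beyond the scatter). Both point the same way, so compound 4 is expected to fall short of compound 1 in this assay, though the size of the loss is uncertain, since the entering (tert-butoxycarbonyl)amino group carries one hydrogen-bond donor, like the group in compound 3, yet lacks its ring. The expected step is a 25-fold higher number from compound 1 to compound 4 (1.40 log units; beyond the scatter), placing compound 4 at an estimated 25 nM, within 6 nM to 120 nM.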

Compound 4, half-maximal inhibitory concentration: 10 nM
For compound 4 the middle estimate is 2.5-fold (0.40 log units) above the measured one; measured number inside the range.
By their numbers in this assay, from the lowest: compound 1; then compounds 2 and 4 (each within the scatter of the next); then compound 3.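

In this assay, the outcome at this position depends on the outer part of the group and not only on its presence: with the carbonyl carbon kept, tert-butoxy in place of cyclohexylamino on that carbon gives a 9.0-fold lower number from compound 3 to compound 4 (0.95 log units; beyond the scatter). For the compounds shown here, putting (tert-butoxycarbonyl)amino in place of hydrogen gives a 1.4-fold higher number from compound 2 to compound 4 (0.15 log units; within the scatter), so this group, unlike the one in compound 3, stays level with hydrogen on the saturated chain carbon. Replacing acetyl(benzyl)amino with this group still gives a 10-fold higher number from compound 1 to compound 4 (1.00 log units; beyond the scatter), which leaves compound 1 alone at the low end, and no evidence is available to explain these differences.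

The compounds shown leave open whether the acetyl or the benzyl part of compound 1 accounts for its standing. Plain acetylamino and benzylamino groups at this position would separate the two, while a free amine would show the outcome without any carbonyl.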